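This account rests on a few compounds, and the source may have more. Where it says the series, first, only, none or still open, it means among the compounds named here.

Measured so far in an ADME assay on HepG2 cells (Homo sapiens) for cytotoxicity, read by CellTiter-Glo and resazurin assay, with a stated time of 72 h; a higher number here means that more compound is needed for the effect, a lower number that less compound is needed:
Compound 1 `CCOC(=O)CCCCCOc1cccc(CN(C(=O)c2ccc(-c3ccc(C(C)=O)s3)cc2)C(C)C)c1` gives > 26000 nM, a limit of this assay.
Compound 2 `CCOC(=O)CCCCCOc1cccc(CN(C(=O)c2ccc(-c3ccc4c(c3)OCCO4)cc2)C(C)C)c1` gives > 24400 nM, a limit of this assay.
Compound 3 `CCOC(=O)CCCCCOc1cccc(CN(C(=O)c2ccc(-c3cc(OC)ccc3F)cc2)C(C)C)c1` gives > 26000 nM, a limit of this assay.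

Compound 3 therefore stands only at a limit in this assay, and the two further values shown sit at limits as well: one at the limit of > 24400 nM in this assay, at which 1 of the 3 values shown sits, and two at the limit of > 26000 nM in this assay, at which 2 of the 3 values shown sit. Compound 4 `CCOC(=O)CCCCCOc1cccc(CN(C(=O)c2ccc(-c3cccc(Cl)c3)cc2)C(C)C)c1` differs from compound 3 by 3-chlorophenyl in place of 2-fluoro-5-methoxyphenyl on an aromatic carbon. The measured steps that bear on this change are those among the three aryl replacements on the same aromatic carbon: a step that the two limits leave unreadable from compound 1 to compound 3, a step that the two limits leave unreadable from compound 2 to compound 3 and a step that the two limits leave unreadable from compound 1 to compound 2. Each of them is unreadable, since both ends of every pair are limits, so no size of any of these steps can be taken from the data. No reading of this assay above the scatter is expected to be resolved for compound 4 either, and the step from compound 3 is estimated as a step that the limit leaves unreadable from compound 3 to compound 4. Compound 4 is accordingly expected to give about 30000 nM in this assay, within a range of 10000 nM to 100000 nM, most likely again reported as a limit.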

Compound 4, half-maximal effective concentration: > 18400 nM
Compound 4 ended at the assay's limit; the forecaster's own chance of this, stated with the estimate: 85%; the middle value is on the limit's open side.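

Compound 1, compound 2, compound 3 and compound 4 all stand only at limits in this assay, so the steps from the first three to compound 4 cannot be read. The compounds shown leave open what half-maximal effective concentration any of these four compounds has.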